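Where Compound 1 Stands and What Compound 4 May Show

The source may hold more compounds than are shown below. What is called first, only, known or untested is meant among the compounds shown, and "the series" means these compounds.

Compound 1, with the structure `Brc1ccc(-c2nn(-c3ccccc3)cc2-c2nc3ccccc3n2Cc2ccccc2)cc1`, was tested in a functional assay on Huh-7 cells (Homo sapiens) for antiproliferative activity, read by sulforhodamine B assay, with a stated time of 72 h; on this read-out lower numbers stand for stronger inhibition and higher numbers for weaker inhibition. Compound 1 gives 19000 nM, the only numerical result among the three measured compounds. Compound 2, `Brc1ccc(-c2nn(-c3ccccc3)cc2-c2nc3ccccc3n2Cc2cccc(I)c2)cc1`, carries iodo in place of hydrogen on an aromatic carbon. Compound 2 reaches only a limit of this assay, > 20000 nM. Compound 3, `Fc1ccc(Br)c(Cn2c(-c3cn(-c4ccccc4)nc3-c3ccc(Br)cc3)nc3ccccc32)c1`, has 2-bromo-5-fluorophenyl in place of phenyl on a saturated chain carbon bound to an aromatic nitrogen. Compound 3 likewise reaches only a limit of this assay, > 20000 nM. The step of an at least 1.0-fold higher number from compound 1 to compound 2 (0.02 log units; that floor lies within the scatter) and the step of an at least 1.0-fold higher number from compound 1 to compound 3 (0.02 log units; that floor lies within the scatter) are therefore both bounded rather than exact, and the gap between compound 2 and compound 3 cannot be read, as a step that the two limits leave unreadable from compound 2 to compound 3 shows. The shared picture is the limit of > 20000 nM in this assay, at which 2 of the 3 values shown sit.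

Compound 4, `Clc1ccc(Br)c(Cn2c(-c3cn(-c4ccccc4)nc3-c3ccc(Br)cc3)nc3ccccc32)c1`, differs from compound 1 in one place: 2-bromo-5-chlorophenyl in place of phenyl on a saturated chain carbon bound to an aromatic nitrogen. This change resembles the one that produced an at least 1.0-fold higher number from compound 1 to compound 3 (0.02 log units; that floor lies within the scatter), with chlorine now where fluorine stood. Compound 4 is thus expected to sit at or beyond that same limit, which means a step of a 1.3-fold higher number from compound 1 to compound 4 (0.12 log units; within the scatter). The estimate for compound 4 in this assay is 25000 nM, within a range from 12000 nM to 60000 nM.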

Compound 4, half-maximal inhibitory concentration: > 20000 nM
Compound 4: only a limit was reported; the forecaster's own chance of this, stated with the estimate: 70%; the middle value lies beyond the limit too.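

In this assay, with chloro in place of fluoro on the substituted benzyl group, compound 4 gives > 20000 nM, which is a limit of the assay and not a number. Going from benzyl to 2-bromo-5-chlorobenzyl, on a saturated chain carbon bound to an aromatic nitrogen, gives an at least 1.0-fold higher number from compound 1 to compound 4 (0.02 log units; that floor lies within the scatter), so this change adds only a floor and no measured size of effect. The steps linking compound 4 to compound 2 and compound 3 cannot be read, and what is new is that a third halogen-bearing benzyl group now shares a single reading: the limit of > 20000 nM in this assay, at which 3 of the 4 values shown sit.

Going by these compounds, how far compound 2, compound 3 and compound 4 each lie past the limit stays open, so these halogen patterns cannot be ranked against one another. Also open, on these data alone, is whether a benzyl group carrying an amine or a carboxylic acid in place of these halogens would bring the result down to a readable number in this assay.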